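The source may hold more compounds than are shown below. What is called first, only, known or untested is meant among the compounds shown, and "the series" means these compounds.

Compound 2 `CN1Cc2c(Cl)cc(Cl)cc2C(c2cccc(NC(=O)[C@H](O)[C@@H](O)[C@H](O)[C@H](O)CO)c2)C1` stands with the lowest number of the two measured here: in an assay on cells (Kidney epithelial cell, kidney) for inhibition of sodium/hydrogen exchanger 3 (Homo sapiens), read by fluorescence, in the presence of a further agent that is not named here (a higher number here means a weaker inhibitor, a lower number a stronger inhibitor), compound 2 gives 50.1 nM, whereas compound 1 `CN1Cc2c(Cl)cc(Cl)cc2C(c2cccc(S(N)(=O)=O)c2)C1` gives 631 nM, a gap that lies beyond the scatter. Compound 3 `CN1Cc2c(Cl)cc(Cl)cc2[C@H](c2cccc(NC(=O)[C@H](O)[C@@H](O)[C@H](O)[C@H](O)CO)c2)C1` differs from compound 2 only in this: the two compounds have the same atoms and bonds; at least one stereo element is drawn with a configuration in one of them and without one in the other: 1 of 5 stereo elements differ; a stereocentre at a saturated ring carbon is drawn without a configuration in compound 2 and S in compound 3. For the measured compounds named here, no measured pair shows what drawing one configuration at that ring carbon does, so the direction of the step is open. The estimated step from compound 2 to compound 3 is a 1.3-fold lower number from compound 2 to compound 3 (0.10 log units; within the scatter). Compound 3 is expected at 40 nM, within a range of 12 nM to 300 nM.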

Compound 3, half-maximal inhibitory concentration: 25.1 nM
The estimate for compound 3 lay 1.6-fold (0.20 log units) above the measured number, and the stated range covers the measured number.
By their numbers in this assay, from the lowest: compounds 3 and 2 (each within the scatter of the next); then compound 1.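

In this assay the step at the saturated ring carbon is a 2.0-fold lower number from compound 2 to compound 3 (0.30 log units; within the scatter), so compound 3, drawn as S, stands level with compound 2, drawn without a configuration. This is the first reading at this ring carbon, and it rests on a single contrast: the fact that one of compounds 2 and 3 is drawn with a defined configuration and the other without, at the place where they differ

The compounds shown leave open how the R configuration at that ring carbon would read. They also leave open how that configuration would read with the hydroxylated amide chain replaced by a carboxylic acid or an amine.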